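This account rests on a few compounds, and the source may have more. Where it says the series, first, only, none or still open, it means among the compounds named here.

Measured so far:
compound 1 `CCCCCOc1ccc(NC(=O)ON=C(C)C)cc1` — 28 nM
compound 2 `CCCCCCCCOc1ccc(NC(=O)ON=C(C)C)cc1` — 2.4 nM

In an assay on H4 cells for inhibition of Fatty-acid amide hydrolase 1 (Homo sapiens) (a lower number here means a stronger inhibitor, a higher number a weaker inhibitor), compound 2 holds the lowest of the two numbers; its nearest neighbour is compound 1, which in this assay gives 28 nM. Compound 3 `CCCCCCCCCOc1ccc(NC(=O)ON=C(C)C)cc1` differs from compound 2 by methyl in place of hydrogen on a saturated chain carbon, eight bonds along the chain from an oxygen on an aromatic ring. Going by the values given here, only one measured step bears on this: a 12-fold lower number from compound 1 to compound 2 (1.07 log units; beyond the scatter), where three chain carbons were added at once. A single further methyl at the chain end is a smaller change, so the expected step of a 1.6-fold lower number from compound 2 to compound 3 (0.20 log units; within the scatter) is a small lowering or none beyond the scatter. Compound 3 is estimated at 1.5 nM, within 0.6 nM to 4 nM.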

Compound 3, half-maximal inhibitory concentration: 2.1 nM
Compound 3: middle estimate off by 1.4-fold (0.15 log units), on the low side, within the range that was stated.
By their numbers in this assay, from the lowest: compounds 3 and 2 (each within the scatter of the next); then compound 1.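

In this assay, methyl in place of hydrogen, eight bonds along the chain from the oxygen on the aromatic ring, gives a 1.1-fold lower number from compound 2 to compound 3 (0.06 log units; within the scatter); at this position, compound 2 and compound 3 therefore cannot be told apart. The large step seen earlier is kept but not clearly extended, with a 13-fold lower number from compound 1 to compound 3 (1.12 log units; beyond the scatter) standing close to a 12-fold lower number from compound 1 to compound 2 (1.07 log units; beyond the scatter). No evidence here accounts for this result. Still open, as far as these compounds go, is how a longer chain would read in this assay, and whether an amine or a carboxylic acid at the chain end would be tolerated.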